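This account rests on a few compounds, and the source may have more. Where it says the series, first, only, none or still open, it means among the compounds named here.

Measured in a functional assay on SK-OV-3 cells (Homo sapiens) for cytotoxicity, read by spectrophotometry, with a stated time of 72 h; on this read-out lower numbers stand for stronger inhibition and higher numbers for weaker inhibition:
compound 1 `COc1ccc(-c2cccc(=O)n2-c2cc(OC)c(OC)c(OC)c2)cc1OC`: 545 nM
compound 2 `COc1cc(-n2c(-c3ccc([N+](=O)[O-])cc3)cccc2=O)cc(OC)c1OC`: 201 nM

Compound 2, at 201 nM, holds the lower of the two numbers. Compound 1 stands at 545 nM. The gap between these two numbers lies beyond the scatter. Compound 3 `COc1cc(-n2c(-c3ccncc3)cccc2=O)cc(OC)c1OC` carries pyridin-4-yl in place of 4-nitrophenyl on an aromatic carbon. Within the data shown here, no measured pair differs in one place, so the size of this step rests on judgement alone. The expected change is a 5.0-fold higher number from compound 2 to compound 3 (0.70 log units; beyond the scatter), towards weaker inhibition and beyond the scatter. For compound 3 the estimate is 1000 nM, with an expected range of 220 nM to 5000 nM.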

Compound 3, half-maximal inhibitory concentration: 1790 nM
Beside the measured number, compound 3's estimate is 1.8-fold (0.25 log units) below it; the measured number falls inside the stated range.
By their numbers in this assay, from the lowest: compound 2; then compound 1; then compound 3.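

Pyridin-4-yl in place of 4-nitrophenyl gives an 8.9-fold higher number from compound 2 to compound 3 (0.95 log units; beyond the scatter) in this assay, the first step in the series that changes one place only. This aromatic carbon, next to the ring nitrogen, therefore does not accept this exchange without a clear move towards weaker inhibition. No supporting measurement bears on the origin of this step.

The step removes the nitro group and brings in a ring nitrogen at once, and the two stay unseparated. Plain phenyl or 4-aminophenyl at this place would help to tell them apart.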